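The source may hold more compounds than are shown below. What is called first, only, known or untested is meant among the compounds shown, and "the series" means these compounds.

Measured so far in a functional assay on cells (Cancer cell lines, Homo sapiens) for inhibition; a lower number here means a stronger inhibitor of growth, a higher number a weaker inhibitor of growth:
- compound 1 `N=C(N)N/N=C/c1c(-c2cc(Cl)sc2Cl)nc2n1CCS2` gives 8710 nM
- compound 2 `N=C(N)N/N=C/c1c(-c2ccsc2)nc2sccn12` gives 15100 nM
- compound 3 `Cc1cn2c(/C=N/NC(=N)N)c(-c3cccs3)nc2s1` gives 4270 nM

Compound 1 is the second highest of these three numbers. Its value lies within the scatter of compound 2 and beyond the scatter of compound 3, which has the lower number.

The next compound is compound 4 `N=C(N)N/N=C/c1c(-c2cccs2)nc2n1CCS2`, which keeps the core of compound 1. Thiophen-2-yl takes the place of 2,5-dichlorothiophen-3-yl on an aromatic carbon (thiophen-2-yl in place of 2,5-dichlorothiophen-3-yl on an aromatic carbon). Among the compounds with values here, no measured pair isolates this change, and the three measured compounds do not share one core, so the evidence is indirect. Compound 3 also carries thiophen-2-yl and gives 4270 nM, while compound 2, also without chlorine on that ring, gives 15100 nM. These two values point in opposite directions around compound 1, so only a small shift in this assay is expected, with a slight lean towards a higher number. The expected change is a 1.3-fold higher number from compound 1 to compound 4 (0.10 log units; within the scatter), which would not clearly stand beyond the scatter. For compound 4 the estimated value is 11000 nM, with an expected range of 4500 nM to 27000 nM.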

Compound 4, concentration for 50% growth inhibition: 19100 nM
For compound 4 the middle estimate is 1.7-fold (0.24 log units) below the measured one; measured number inside the range.
By their numbers in this assay, from the lowest: compound 3; then compounds 1, 2 and 4 (each within the scatter of the next, the first and the last beyond it).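

In this assay, within the data shown here, the pair of compound 1 and compound 4 is the first to isolate a single change on one core: thiophen-2-yl in place of 2,5-dichlorothiophen-3-yl on an aromatic carbon gives a 2.2-fold higher number from compound 1 to compound 4 (0.34 log units; beyond the scatter), a modest step, but enough to show that this position is sensitive to the group it carries, with the dichlorinated ring giving the lower number of the two. The change is compound, however: both chlorine atoms leave, the heavy-atom count of the group falls from 7 to 5, and the point of attachment on the thiophene moves from the 3-yl to the 2-yl, so this single step cannot assign the shift to any one of these differences. No measurement available here bears on the reason for the step.

Still open, from the compounds shown here alone, is whether unsubstituted thiophen-3-yl or a thiophene with a single chlorine on the core of compound 1 would align with compound 1 or with compound 4. Going by these compounds, it is also open whether the same step holds on the cores of compound 2 and compound 3, and how a phenyl ring or a thiophene carrying an amine or a carboxylic acid would read at this position.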